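Cyclohexyl to 2-isopropoxyethyl on a series at its limit

The source may report more compounds than this note shows. Statements on the series, on what has been measured and on what is new or still open speak of the compounds shown alone.

Compound 1 (`COc1cccc(OC)c1C(=O)Nc1c[nH]nc1C(=O)NCc1ccccn1`) gives > 50000 nM in an ADME assay on MRC5 cells (Homo sapiens) for inhibition, with a stated time of 72 h (a higher number here means that more compound is needed for the effect, a lower number that less compound is needed), and that is a limit of the assay, not a number. Compound 2 (`COc1cccc(OC)c1C(=O)Nc1c[nH]nc1C(=O)NCC1CCCCC1`) gives > 50000 nM in this assay and that too is only a limit. Among the compounds with values here, compound 2 therefore has no numeric position, and the one other value shown is also a limit.

The next structure is compound 3 (`COc1cccc(OC)c1C(=O)Nc1c[nH]nc1C(=O)NCCCOC(C)C`), reached through (2-isopropoxyethyl in place of cyclohexyl on a saturated chain carbon bound to an amide-type nitrogen). In words, 2-isopropoxyethyl stands in place of cyclohexyl on a saturated chain carbon bound to an amide-type nitrogen.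

Within the data shown here, one measured step bears on this place: a step that the two limits leave unreadable from compound 1 to compound 2, with cyclohexyl in place of pyridin-2-yl. No size can be carried over from it. For compound 3, no step beyond the scatter is expected in this assay because of the limit of > 50000 nM in this assay, at which 2 of the 2 values shown sit, and a further limit is the likeliest report. The expected step is a number no higher from compound 2 to compound 3 (the limit leaves the size open) as an estimate only. Compound 3 is estimated at 50000 nM with 25000 nM to 100000 nM as the expected range.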

Compound 3, half-maximal effective concentration: > 50000 nM
Compound 3: only a limit was reported (the forecaster's own chance of this, stated with the estimate: 85%); the middle value lies on the limit itself.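

In this assay compound 3 gives > 50000 nM, which is a limit of the assay. No step among compound 1, compound 2 and compound 3 can be read, all three resting on the same limit: the limit of > 50000 nM in this assay, at which 3 of the 3 values shown sit.

Still open, from the compounds shown here alone, is whether pyridin-2-yl, cyclohexyl or 2-isopropoxyethyl at this place makes any difference to the half-maximal effective concentration.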